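The compounds below may be only part of what the source reports. "The series", "measured", "known", "first", "only" and "open" are said of these compounds alone.

Measured compounds in the series, all in a physicochemical assay for lipophilicity, in phosphate buffer, measured as octanol-water partition, with a stated time of 24 h; on this read-out lower numbers stand for lower lipophilicity and higher numbers for higher lipophilicity:

compound 1 `O=C(CN1C(=O)c2ccccc2C1=O)NN1C(=O)CSC1c1c(F)cccc1Cl` gives 3.79
compound 2 `O=C(CN1C(=O)c2ccccc2C1=O)NN1C(=O)CSC1c1cccnc1` gives 1.25
compound 3 `O=C(CN1C(=O)c2ccccc2C1=O)NN1C(=O)CSC1c1ccco1` gives 1.13

Compound 1 carries the highest of the three numbers; its nearest neighbour is compound 2, with a number 2.54 log units lower from compound 1 to compound 2 (beyond the scatter), and the furthest is compound 3, with a number 2.66 log units lower from compound 1 to compound 3 (beyond the scatter). Between compound 2 and compound 3 the gap is a number 0.12 log units lower from compound 2 to compound 3 (within the scatter), so the two heteroaryl analogues cannot be ordered against each other.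

Compound 4 `COc1ccc(C2SCC(=O)N2NC(=O)CN2C(=O)c3ccccc3C2=O)cc1` is not yet measured in this assay. Relative to compound 1 the change is 4-methoxyphenyl in place of 2-chloro-6-fluorophenyl on a saturated ring carbon. Within the data shown here, the two measured steps from compound 1 both swap the same 2-chloro-6-fluorophenyl group for a smaller heteroaryl ring and both give large drops; neither places a substituted carbon-only aromatic ring at that saturated ring carbon, so there is no direct precedent for 4-methoxyphenyl. The entering group keeps a six-membered carbon-only aromatic ring and the same heavy-atom count but exchanges two halogens for one methoxy oxygen acceptor. A drop from compound 1 is therefore expected, but one clearly smaller than a number 2.54 log units lower from compound 1 to compound 2 (beyond the scatter) or a number 2.66 log units lower from compound 1 to compound 3 (beyond the scatter); the expected step is a number 1.09 log units lower from compound 1 to compound 4 (beyond the scatter). Compound 4 is estimated at 2.7, with a range from 2.1 to 3.3.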

Compound 4, partition coefficient: 1.97
Compound 4: middle estimate off by 0.73 log units, on the high side; measured number outside the range, below it.
By their numbers in this assay, from the lowest: compounds 3 and 2 (each within the scatter of the next); then compound 4; then compound 1.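

In this assay, keeping a six-membered aromatic ring of carbon only and the same heavy-atom count on the saturated ring carbon does not hold the number near that of compound 1: 4-methoxyphenyl in place of 2-chloro-6-fluorophenyl is still a large step (a number 1.82 log units lower from compound 1 to compound 4 (beyond the scatter)). The position also separates 4-methoxyphenyl from both heteroaryl groups, by modest steps (a number 0.84 log units higher from compound 3 to compound 4 (beyond the scatter); a number 0.72 log units higher from compound 2 to compound 4 (beyond the scatter)), so the heteroaryl analogues no longer mark the only drop at this carbon and compound 4 takes an intermediate place, nearer to them than to compound 1. Nothing at hand gives a reason for these steps.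

Open: removal of chlorine, removal of fluorine and addition of methoxy all occur in the single change from compound 1 to compound 4, so the compounds shown do not divide the step among them. Also open, on these data alone, is where a plain phenyl, a 4-chlorophenyl, or a phenyl ring bearing an amine or a carboxylic acid would fall in this assay at this saturated ring carbon.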